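The source may report more compounds than this note shows. Statements on the series, on what has been measured and on what is new or still open speak of the compounds shown alone.

Working notes on a four-membered set of amides sharing one core, profiled for inhibition of the dopamine transporter.

Compound 1 `O=C(NCCCN1CCN(c2ccccn2)CC1)c1cccc2ccccc12` bears a pyridin-2-yl on an amine nitrogen in a ring. In an assay on HEK293 cells for inhibition of sodium-dependent dopamine transporter (Homo sapiens), read by scintillation counting (a higher number here means a weaker inhibitor, a lower number a stronger inhibitor), compound 1 returns only a limit, > 10000 nM. Compound 2 `O=C(NCCCN1CCN(c2ncccn2)CC1)c1cccc2ccccc12` is the product of one change to compound 1, (pyrimidin-2-yl in place of pyridin-2-yl on an amine nitrogen in a ring). In this assay compound 2 likewise returns only a limit, > 10000 nM. The pair therefore yields a step that the two limits leave unreadable from compound 1 to compound 2.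

Compound 3 `O=C(NCCCN1CCN(c2ccccn2)CC1)c1ccc2ccccc2c1` holds the same atoms as compound 1, joined differently; the difference between the two cores is not broken down here. In this assay compound 3 also returns only a limit, > 10000 nM. Going by the values given here, every measured value of the set sits at the limit of > 10000 nM in this assay, at which 3 of the 3 values shown sit, so no measured step in it has a readable size.

Compound 4 `O=C(NCCCN1CCN(c2ncccn2)CC1)c1ccc2ccccc2c1` has not been measured. It stands to compound 3 as compound 2 stands to compound 1, through (pyrimidin-2-yl in place of pyridin-2-yl on an amine nitrogen in a ring), with the place of the change described in identical terms in both pairs, so this is the same change made a second time.

For the transition from compound 3 to compound 4 in this assay a step that the limit leaves unreadable from compound 3 to compound 4 is expected. This expectation rests on the measured pair, where the same change left both compound 1 and compound 2 at the limit of > 10000 nM in this assay, at which 3 of the 3 values shown sit, with no readable movement in either direction. Compound 4 is accordingly estimated at 20000 nM in this assay, within a band from 8000 nM to 60000 nM, and most probably reported once more as a limit rather than a number.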

Compound 4, half-maximal inhibitory concentration: > 10000 nM
Compound 4: a limit, no number (the forecaster's own chance of this, stated with the estimate: 85%); the middle value is on the limit's open side.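

In this assay compound 4 returns only a limit, > 10000 nM. Compound 3 also stands at a limit, so no size can be read for the step from compound 3 to compound 4, and the set remains at one limit: the limit of > 10000 nM in this assay, at which 4 of the 4 values shown sit.

The compounds shown leave open how strong any of them is in this assay, and whether pyrimidin-2-yl in place of pyridin-2-yl moves the value at all.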